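The source may report more compounds than this note shows. Statements on the series, on what has been measured and on what is new or still open speak of the compounds shown alone.

Values from an ADME assay on ECV-304 cells (Homo sapiens) for cytotoxicity, read by MTT assay, with a stated time of 72 h (on this read-out lower numbers stand for stronger inhibition and higher numbers for weaker inhibition), so far:

compound 1 `COc1cc(C2=C(c3cc(C)c(OC)c(C)c3)C(O)CC2=O)cc(OC)c1OC` gives > 100 ug/mL (a limit)
compound 2 `COc1ccc(C2=C(c3cc(OC)c(OC)c(OC)c3)C(=O)C(O[SiH2]C(C)(C)C)C2)cc1OC(C)C` gives > 100 ug/mL (a limit)
compound 3 `COc1ccc(C2=C(c3cc(OC)c(OC)c(OC)c3)C(=O)C(OC(C)=O)C2)cc1Cl` gives 3.5 ug/mL (a number)

Compound 1 gives > 100 ug/mL as a limit and not a number, and so stands on the limit of > 100 ug/mL in this assay, at which 2 of the 3 values shown sit, in this series. The next compound to be read is compound 4 `COc1cc(C2=C(c3cc(C)c(OC)c(C)c3)C(O[SiH2]C(C)(C)C)CC2=O)cc(OC)c1OC` and the change from compound 1 is a group of 5 heavy atoms (4 carbon, 1 silicon; no ring) in place of a hydrogen atom, on an oxygen on a saturated carbon with the rest of the structure unchanged. Among the measured compounds shown here, no step between measured compounds is available to size this change. Compound 2 also holds a group with silicon, and it gives > 100 ug/mL as a limit. Compound 3 goes against that uniform run, since it gives 3.5 ug/mL as a real number. The expected step is an at least 1.2-fold lower number from compound 1 to compound 4 (0.09 log units; that floor lies within the scatter) and it should stay within the scatter, with no clear direction. For compound 4 the estimated value is 80 ug/mL with an expected range from 15 ug/mL to 200 ug/mL in this assay for now.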

Compound 4, half-maximal inhibitory concentration: 15 ug/mL
Compound 4: the middle estimate sits 5.3-fold (0.73 log units) above what was measured, within the range that was stated.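

In this assay there is an at least 6.6-fold lower number from compound 1 to compound 4 (0.82 log units; beyond the scatter) on placing a group of 5 heavy atoms (4 carbon, 1 silicon; no ring) in place of a hydrogen atom, on an oxygen on a saturated carbon. This gives the series its first reading of a single change, and it shows that this oxygen is not silent to substitution on the core of compound 1. As far as these compounds go, compound 1 gives > 100 ug/mL as a limit and not a number, so the step is only a floor and its full size stays unknown: the limit of > 100 ug/mL in this assay, at which 2 of the 4 values shown sit.

From the compounds shown here alone, whether a group without silicon, such as a longer carbon chain, or an amine in place of this oxygen would give a like step stays open. Also open, going by these compounds, is whether the same change would act alike on the cores of compound 2 and compound 3, which differ from compound 4 in more than one place.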